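Urea series: removing the aryl group from the pyrazole nitrogen

This account rests on a few compounds, and the source may have more. Where it says the series, first, only, none or still open, it means among the compounds named here.

Measured compounds:
compound 1 `CC(C)(C)c1cc(NC(=O)Nc2cc(C(F)(F)F)cc(C(F)(F)F)c2)n(-c2ccc(F)cc2)n1`: 0.5 degrees C
compound 2 `CC(C)(C)c1cc(NC(=O)Nc2cc(F)cc(F)c2)n(-c2ccccc2)n1`: 3 degrees C
compound 3 `Cc1ccc(-n2nc(C(C)(C)C)cc2NC(=O)Nc2cc(F)cc(F)c2)cc1`: 2.8 degrees C

In an assay on isolated protein for inhibition of STE20-like serine/threonine-protein kinase (Homo sapiens), read by thermal shift assay, tested at 10 uM (a lower number here means that the compound stabilises the target less, a higher number that the compound stabilises the target more against heat), compound 3 gives 2.8 degrees C, the second highest of the three numbers, close to compound 2 and well clear of compound 1. The step to compound 4 `Cn1nc(C(C)(C)C)cc1NC(=O)Nc1cc(F)cc(F)c1` is methyl in place of 4-methylphenyl on an aromatic nitrogen. Going by the values given here, the only step measured in one place, a number 0.20 degrees C lower from compound 2 to compound 3 (within the scatter), concerns a substituent on that same aryl ring rather than the ring itself, and it stayed within the scatter. Compound 1 and compound 2 differ in two places, so their gap cannot be assigned. Among the compounds with values here, no measured step speaks to removing the whole ring; the change is large, and a loss beyond the scatter is judged more likely than a gain. Compound 4 is expected to give 1.5 degrees C, between 0 degrees C and 3 degrees C, a step of a number 1.3 degrees C lower from compound 3 to compound 4 (beyond the scatter).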

Compound 4, shift of the target's melting temperature: 1.2 degrees C
Estimate against measurement, compound 4: 0.30 degrees C above, and the stated range covers the measured number.
By their numbers in this assay, from the lowest: compounds 1 and 4 (each within the scatter of the next); then compounds 3 and 2 (each within the scatter of the next).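

At this aromatic nitrogen, this assay responds to the loss of the ring itself: methyl in place of 4-methylphenyl gives a number 1.6 degrees C lower from compound 3 to compound 4 (beyond the scatter) and methyl in place of phenyl gives a number 1.8 degrees C lower from compound 2 to compound 4 (beyond the scatter) in the same direction. Going by these compounds alone, the earlier one-place change on this aryl ring stayed within the scatter, so these are the first steps at this position to pass beyond it. Nothing measured here explains the drop.

Still open, on these data alone, is whether a benzyl or a cyclohexyl group at this nitrogen would restore the number, and whether an amine or a carboxylic acid on the aryl ring would be tolerated.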